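Swapping a hydroxyphenylmethyl arm for isopropyl on a sulfonamide core

A few compounds are considered here, and "the series" means these few. Any claim that something is new, unique, unknown or untested is made for them only; others in the source may bear on it.

Measured so far:
- Compound 1, `C[C@@H](c1ccc(Cl)cc1)N1Cc2cncn2C(C[C@@H](O)c2ccccc2)S1(=O)=O`: 234 nM
- Compound 2, `CC(C)CC1n2cncc2CN([C@H](C)c2ccc(Cl)cc2)S1(=O)=O`: 204 nM
- Compound 3, `C[C@@H](c1ccc(Cl)cc1)N1Cc2cncn2C(C[C@H](O)c2ccccc2)S1(=O)=O`: 182 nM

Of the compounds shown here, three have been tested in an assay on cells for inhibition of cytochrome P450 11B1, mitochondrial (Homo sapiens); on this read-out lower numbers stand for stronger inhibition and higher numbers for weaker inhibition. Compound 3 gives 182 nM, the lowest of the three numbers, but its neighbours sit close: compound 2 gives 204 nM and compound 1 gives 234 nM, both within the scatter of compound 3. Among the compounds with values here, the only step between compounds that differ in one place, a 1.3-fold lower number from compound 1 to compound 3 (0.11 log units; within the scatter), is the inversion of a single stereocentre and stays within the scatter, consistent with the fact that one of compounds 1 and 3 is drawn with a defined configuration and the other without, at the place where they differ.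

The next compound, compound 4, `CC(C)CC1n2cncc2CN([C@@H](C)c2ccc(Cl)cc2)S1(=O)=O`, differs from compound 3 as follows: isopropyl in place of hydroxy(phenyl)methyl on a saturated chain carbon bound to a saturated ring carbon. Within the data shown here, no measured step touches this change; the one known step concerns a stereocentre, not the replacement of one chain group by another, and the three numbers so far span a narrow band. With nothing in the data pointing either way, the step of a 1.1-fold higher number from compound 3 to compound 4 (0.04 log units; within the scatter) is expected to be none beyond the scatter. Compound 4 is therefore estimated at 200 nM in this assay, with a range from 90 nM to 450 nM.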

Compound 4, half-maximal inhibitory concentration: 76 nM
Compound 4: the middle estimate sits 2.6-fold (0.42 log units) above what was measured; the whole stated range lies above it.
By their numbers in this assay, from the lowest: compound 4; then compounds 3, 2 and 1 (each within the scatter of the next).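

In this assay, within the data shown here, the exchange of hydroxy(phenyl)methyl for isopropyl, on a saturated chain carbon bound to a saturated ring carbon, gives the first steps beyond the scatter: a 2.4-fold lower number from compound 3 to compound 4 (0.38 log units; beyond the scatter) and a 3.1-fold lower number from compound 1 to compound 4 (0.49 log units; beyond the scatter). A stereocentre at a saturated chain carbon, drawn R in compound 2 and S in compound 4, also gives a step beyond the scatter, a 2.7-fold lower number from compound 2 to compound 4 (0.43 log units; beyond the scatter), whereas the inversion in the hydroxy-bearing arm stays within it, a 1.3-fold lower number from compound 1 to compound 3 (0.11 log units; within the scatter). This reading of the configuration comes with one qualification: the fact that one of compounds 2 and 4 is drawn with a defined configuration and the other without, at the place where they differ.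

The compounds shown remove the hydroxy group and the six-membered aromatic ring together, so they leave open which of the two losses accounts for the lower numbers. As far as these compounds go, how a benzyl group, an amine or a longer chain would read at this place in this assay also remains open.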